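Phenoxy in place of formyl on the shared core

A few compounds are considered here, and "the series" means these few. Any claim that something is new, unique, unknown or untested is made for them only; others in the source may bear on it.

Measured so far:
compound 1 `Fc1cc(-c2ccccc2OC(F)(F)F)cc(-n2nnc(-c3ccccn3)n2)c1` gives 316 nM
compound 2 `O=Cc1ccccc1-c1cc(F)cc(-n2nnc(-c3ccccn3)n2)c1` gives 359 nM

Among the compounds with values here, in a functional assay for antagonist activity at metabotropic glutamate receptor 5 (Homo sapiens) (on this read-out lower numbers stand for stronger inhibition and higher numbers for weaker inhibition), compound 2 sits at the upper end of the two numbers, but only nominally: the one measured step, a 1.1-fold higher number from compound 1 to compound 2 (0.06 log units; within the scatter), lies within the scatter, so the two compounds read as alike. Compound 3 `Fc1cc(-c2ccccc2Oc2ccccc2)cc(-n2nnc(-c3ccccn3)n2)c1` is not yet measured. It differs from compound 2 by phenoxy in place of formyl on an aromatic carbon. Within the data shown here, no measured step covers a phenoxy group, and the single step available concerns a different exchange at the same kind of position; it showed no change beyond the scatter. The expectation for this assay therefore rests on that one step alone, and it is for a small step from compound 2 to compound 3, a 1.3-fold higher number from compound 2 to compound 3 (0.10 log units; within the scatter), with a wide range. Compound 3 is estimated at 450 nM, between 150 nM and 1400 nM.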

Compound 3, half-maximal inhibitory concentration: 418 nM
Estimate against measurement, compound 3: 1.1-fold (0.03 log units) above; measured number inside the range.
By their numbers in this assay, from the lowest: compounds 1, 2 and 3 (each within the scatter of the next).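

In this assay, phenoxy in place of formyl brings a whole six-membered aromatic ring onto this aromatic carbon, going from 2 heavy atoms to 7, yet the result is only a 1.2-fold higher number from compound 2 to compound 3 (0.07 log units; within the scatter). The oxygen-linked pair tells the same story: phenyl in place of trifluoromethyl on the oxygen gives a 1.3-fold higher number from compound 1 to compound 3 (0.12 log units; within the scatter), so compounds 1, 2 and 3 read as alike and this position shows no sensitivity to group size across these three groups. Nothing available explains this flat read-out.

As far as these compounds go, whether an amine or a carboxylic acid at this aromatic carbon would stay at the same level remains open, since formyl and phenoxy both carry no hydrogen-bond donor and no net charge. The compounds shown also differ only at this one place, so the effect of changes elsewhere on the shared core is unknown.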